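The source may hold more compounds than are shown below. What is called first, only, known or untested is meant among the compounds shown, and "the series" means these compounds.

Compound 1 `CCOC(=O)[C@H](CCC(=O)O)NC(=O)c1ccc(Sc2nc3cc(N)cc(N)c3nc2-c2ccccc2)cc1`: < 100000 nM
Compound 2 `Nc1cc(N)c2nc(-c3ccccc3)c(Sc3ccc(F)cc3)nc2c1`: 49000 nM
Compound 3 `CCOC(=O)[C@H](CCC(=O)O)NC(=O)c1ccc(CNc2nc3cc(N)cc(N)c3nc2-c2ccccc2)cc1`: < 100000 nM

Three compounds built on the same core were tested in a functional assay on KM12 cells (Homo sapiens) for inhibition, read by sulforhodamine B assay, with a stated time of 48 h; a lower number here means a stronger inhibitor of growth, a higher number a weaker inhibitor of growth. For compound 1 the result < 100000 nM is a limit of the assay and not a number. Compound 3 also reaches only a limit, < 100000 nM. Among the compounds with values here, compound 2 is thus the one compound with a measured figure, giving 49000 nM in this assay. The other two results sit at the limit of < 100000 nM in this assay, at which 2 of the 3 values shown sit. Within the data shown here, since no two measured compounds differ in a single place, no step between measured values can be drawn, and nothing in these data shows which way a single change moves the read-out.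

Compound 4 `Nc1cc(N)c2nc(-c3ccccc3)c(NCc3ccc(F)cc3)nc2c1` is the compound not yet measured. It differs from compound 2 by (4-fluorobenzyl)amino in place of (4-fluorophenyl)sulfanyl on an aromatic carbon. Among the measured compounds shown here, with no measured step to lean on, the size of the change from compound 2 to compound 4 is expected to be small, no larger than the usual scatter, in either direction. Compound 4 is therefore estimated at 50000 nM, with a range from 15000 nM to 160000 nM, so that the expected step from compound 2 is a 1.0-fold higher number from compound 2 to compound 4 (0.01 log units; within the scatter).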

Compound 4, concentration for total growth inhibition: 7410 nM
For compound 4 the middle estimate is 6.7-fold (0.83 log units) above the measured one; measured number below the stated range.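

In this assay, putting (4-fluorobenzyl)amino in place of (4-fluorophenyl)sulfanyl on this aromatic carbon, next to the ring nitrogen and ortho to a phenyl group, gives a 6.6-fold lower number from compound 2 to compound 4 (0.82 log units; beyond the scatter). Within the data shown here, this is the only step in the set that can be read, and it shows that the read-out responds to the group at this position. The entering group differs from the leaving one in its link to the ring, in its heavy atoms and in carrying a hydrogen-bond donor, and this single step does not separate these differences. The remaining results yield no readable step, since they are limits of the assay and not numbers: the limit of < 100000 nM in this assay, at which 2 of the 4 values shown sit.

The compounds shown leave open whether the change in the read-out follows the nitrogen or the added carbon, which a (4-fluorophenyl)amino group, or a (4-fluorobenzyl)sulfanyl group, at the same position would help to separate. Among these compounds, they also leave open what the fluorine on the benzyl ring contributes, as no compound here carries a chlorine, a methoxy group or a plain hydrogen in its place.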